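Replacing an Amide by a Cyclobutylmethyl Ester

The source may report more compounds than this note shows. Statements on the series, on what has been measured and on what is new or still open speak of the compounds shown alone.

Of the compounds shown here, three sharing one core have been tested in an assay on membranes from HeLa cells for displacement of a labelled ligand from adenosine receptor A3 (Homo sapiens), read by scintillation counting, with a stated time of 180 min, tested at 1 uM; a lower number here means less inhibition, a higher number more inhibition at the concentration tested (going by the name of the read-out). Compound 1 `CC1=C(C(=O)OC(C)(C)C)C(c2ccoc2)NC(=O)N1C` gives 12%. Compound 2 `CC1=C(C(N)=O)C(c2ccoc2)NC(=O)N1` gives 2%, and compound 3 `CC1=C(C(N)=O)C(c2ccsc2)NC(=O)N1` gives 1%. Compound 3 stands at the low end of these three numbers: the step of a number 1 percentage points lower from compound 2 to compound 3 (within the scatter) lies within the scatter, whereas the gap to compound 1 lies beyond it.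

The next compound, compound 4 `CC1=C(C(=O)OCC2CCC2)C(c2ccsc2)NC(=O)N1`, differs from compound 3 by cyclobutylmethoxy in place of amino on a carbonyl carbon. Going by the values given here, no measured step changes this part of the molecule on its own. Among the compounds with values here, the only comparison that touches the carbonyl substituent is compound 1 against compound 2, which differ in two places at once; compound 1, carrying an ester there, shows a higher number than compound 2, which carries an amide. Within the data shown here, the one measured step, a number 1 percentage points lower from compound 2 to compound 3 (within the scatter), concerns a different site and gives no guidance here.

A modest rise is therefore expected, with compound 4 estimated at 10%, within a range from 0% to 25%, meaning an expected step of a number 9 percentage points higher from compound 3 to compound 4 (within the scatter).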

Compound 4, a percentage reported as inhibition, at one concentration (the size of the read-out at that concentration, not a potency): 2%
The estimate for compound 4 lay 8 percentage points above the measured number; low and high end bracket the measured number.
By their numbers in this assay, from the lowest: compounds 3, 2, 4 and 1 (each within the scatter of the next, the first and the last beyond it).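

Going by these compounds alone, at this carbonyl carbon, the exchange of amino for cyclobutylmethoxy gives a number 1 percentage points higher from compound 3 to compound 4 (within the scatter) in this assay and is the first measured change made at this site on its own. Although the entering group is much larger, carries a four-membered ring and has no hydrogen-bond donor, this single exchange moves the number by no more than the usual scatter, and the ester in compound 4 brings no measurable gain at the tested concentration. No measurement available here explains this outcome.

From the compounds shown here alone, whether a smaller ester such as methyl ester, a carboxylic acid or a longer chain on the ester oxygen would behave the same way at this carbonyl carbon remains open. Also open, going by these compounds, is whether cyclobutylmethoxy would give a similar number with furan-3-yl in place of thiophen-3-yl on the shared core.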